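The source may report more compounds than this note shows. Statements on the series, on what has been measured and on what is new or still open speak of the compounds shown alone.

Compound 1 `COc1cc(-c2nnc3n2NC(c2cccs2)C(C(=O)c2ccccc2)S3)cc(OC)c1OC` was examined in a functional assay on HepG2 cells (Homo sapiens) for cytotoxicity, read by MTT assay, with a stated time of 48 h; a lower number here means a stronger inhibitor, a higher number a weaker inhibitor. In this assay compound 1 gives only a limit, > 100000 nM. Compound 2 `COc1cc(-c2nnc3n2NC(c2ccco2)C(C(=O)c2ccco2)S3)cc(OC)c1OC` also gives only a limit in this assay, > 100000 nM. Compound 1 therefore stands at the limit of > 100000 nM in this assay, at which 2 of the 2 values shown sit. Compound 3 `COc1ccc(C(=O)C2Sc3nnc(-c4cc(OC)c(OC)c(OC)c4)n3NC2c2cccs2)cc1` has not yet been measured; it differs from compound 1 by methoxy in place of hydrogen on an aromatic carbon. With every measured value sitting at the limit, no step beyond the usual scatter is expected, and the change is estimated as a step that the limit leaves unreadable from compound 1 to compound 3. Compound 3 is accordingly expected to give about 150000 nM, most likely between 50000 nM and 500000 nM.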

Compound 3, half-maximal inhibitory concentration: 68000 nM
The estimate for compound 3 lay 2.2-fold (0.34 log units) above the measured number; the range from low to high includes it.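

Among these compounds, with methoxy in place of hydrogen on the phenyl of the benzoyl group, compound 3 gives the first true number in this assay, and the change reads as an at least 1.4-fold lower number from compound 1 to compound 3 (0.16 log units; that floor lies within the scatter) for this position. That step is only a floor, since the entry for compound 1 is a limit and not a number: the limit of > 100000 nM in this assay, at which 2 of the 3 values shown sit. The compounds shown leave open whether methoxy here truly shifts the value beyond the scatter, and what an amine, a hydroxyl or a carboxylic acid at this place would give.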